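Moving the bromine: from compound 2 to compound 3

This account rests on a few compounds, and the source may have more. Where it says the series, first, only, none or still open, it means among the compounds named here.

compound 1 `COc1cccc(/C=C2\CCC/C(=C\c3ccccc3Cl)C2=O)c1OC`: 11700 nM
compound 2 `COc1cccc(/C=C2\CCC/C(=C\c3ccccc3Br)C2=O)c1OC`: 10800 nM

Both values come from a functional assay on HT-1080 cells (Homo sapiens) for cytotoxicity, read by MTT assay, with a stated time of 72 h; on this read-out higher numbers stand for weaker inhibition and lower numbers for stronger inhibition. Compound 2, at 10800 nM, sits level with compound 1, and the two numbers lie within the usual scatter of repeated measurements. Compound 3 `COc1cccc(/C=C2\CCC/C(=C\c3cccc(Br)c3)C2=O)c1OC` has the same atoms as compound 2, joined differently: 3-bromophenyl in place of 2-bromophenyl on a double-bonded chain carbon bound to a double-bonded ring carbon. In words, 3-bromophenyl stands in place of 2-bromophenyl on a double-bonded chain carbon bound to a double-bonded ring carbon. Among the compounds with values here, only one measured step bears on this change, a 1.1-fold lower number from compound 1 to compound 2 (0.03 log units; within the scatter). Within the data shown here, that step swaps chloro for bromo and does not move the halogen, and no measured compound carries a 3-bromophenyl group. The data therefore give no direction, and no step beyond the scatter is expected in this assay. The estimated step is a 1.1-fold lower number from compound 2 to compound 3 (0.03 log units; within the scatter). For compound 3 the expected value is 10000 nM, with an estimated range of 4000 nM to 25000 nM.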

Compound 3, half-maximal inhibitory concentration: 12200 nM
For compound 3 the middle estimate is 1.2-fold (0.09 log units) below the measured one; measured number inside the range.
By their numbers in this assay, from the lowest: compounds 2, 1 and 3 (each within the scatter of the next).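

In this assay, within the data shown here, moving the bromine shows a 1.1-fold higher number from compound 2 to compound 3 (0.05 log units; within the scatter) and so gives the first reading of where the halogen sits, not just which halogen it is. Changing the halogen and its place together shows a 1.0-fold higher number from compound 1 to compound 3 (0.02 log units; within the scatter) and likewise stays inside the scatter. At this place on a double-bonded chain carbon bound to a double-bonded ring carbon, 2-chlorophenyl, 2-bromophenyl and 3-bromophenyl therefore cannot be told apart in this cell test, and nothing available offers an explanation for that.

Going by these compounds, all three compounds carry a halogen on this phenyl ring, so it remains open whether an amine or a carboxylic acid there would give a clearly different number. On these data alone, the rest of the shared core is identical throughout, so what its groups contribute also remains unknown.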